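Hydroxy on the four-membered ring: compound 3 to compound 4

A few compounds are considered here, and "the series" means these few. Any claim that something is new, unique, unknown or untested is made for them only; others in the source may bear on it.

Measured so far:
- compound 1, `COc1ccc(C2C(O)C(=O)N2c2cc(OC)c(OC)c(OC)c2)cc1`: 12 nM
- compound 2, `COc1cc(N2C(=O)C(O)C2c2ccc(SC)cc2)cc(OC)c1OC`: 15 nM
- compound 3, `COc1ccc(C2CC(=O)N2c2cc(OC)c(OC)c(OC)c2)cc1O`: 521 nM

In a functional assay on HT-29 cells (Homo sapiens) for inhibition, read by sulforhodamine B assay, with a stated time of 72 h (a higher number here means a weaker inhibitor, a lower number a stronger inhibitor), compound 3 gives the highest number of the three; compound 1 and compound 2 sit well lower, and their own difference, a 1.3-fold higher number from compound 1 to compound 2 (0.10 log units; within the scatter), is within the scatter. Compound 4, `COc1ccc(C2C(O)C(=O)N2c2cc(OC)c(OC)c(OC)c2)cc1O`, differs from compound 3 by hydroxy in place of hydrogen on a saturated ring carbon. Among the measured compounds shown here, no measured step isolates this change. Compound 1 already carries the hydroxy on the saturated ring carbon and gives 12 nM, but it also differs from compound 3 in the aryl group, so its value can only hint at direction. A step toward lower numbers is expected, a 13-fold lower number from compound 3 to compound 4 (1.11 log units; beyond the scatter), since compound 1 gives 12 nM. Compound 4 is estimated at 40 nM, range 8 nM to 200 nM.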

Compound 4, half-maximal inhibitory concentration: 463 nM
Compound 4: middle estimate off by 12-fold (1.06 log units), on the low side, and the stated range ends below it.
By their numbers in this assay, from the lowest: compounds 1 and 2 (each within the scatter of the next); then compounds 4 and 3 (each within the scatter of the next).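

In this assay hydroxy in place of hydrogen on the saturated ring carbon gives little change (a 1.1-fold lower number from compound 3 to compound 4 (0.05 log units; within the scatter)), so with the 3-hydroxy-4-methoxyphenyl group present this position does not shift the number beyond the scatter. The large steps come from the aryl group: hydroxy in place of hydrogen on an aromatic carbon (a 39-fold higher number from compound 1 to compound 4 (1.59 log units; beyond the scatter)) and 3-hydroxy-4-methoxyphenyl in place of 4-(methylsulfanyl)phenyl (a 31-fold higher number from compound 2 to compound 4 (1.49 log units; beyond the scatter)). No evidence at hand accounts for these steps.

Among the compounds shown here, compound 1 has no counterpart here without the hydroxy on the saturated ring carbon, so that change remains unread with its aryl group. On these data alone, an amine in place of hydroxy on that ring carbon also remains open.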